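The source may report more compounds than this note shows. Statements on the series, on what has been measured and on what is new or still open speak of the compounds shown alone.

Notes on the series. Compound 1 `Cn1cc(C2=C(c3n[nH]c4ncccc34)C(=O)NC2=O)c2ccccc21` carries a hydrogen on the aromatic nitrogen of the shared core. In a functional assay on K562 cells (Homo sapiens) for antiproliferative activity, read by MTT assay, with a stated time of 48 h (on this read-out lower numbers stand for stronger inhibition and higher numbers for weaker inhibition), compound 1 gives only a limit, > 100000 nM, and no number (the limit of > 100000 nM in this assay, at which 1 of the 3 values shown sits). Compound 2 `Cn1cc(C2=C(c3nn(CCCCn4ccnc4)c4ncccc34)C(=O)NC2=O)c2ccccc21` places a 4-(1H-imidazol-1-yl)butyl on that nitrogen, and in this assay compound 2 gives 31800 nM. Compound 3 `CN1CCN(CCCn2nc(C3=C(c4cn(C)c5ccccc45)C(=O)NC3=O)c3cccnc32)CC1` places a 3-(4-methylpiperazin-1-yl)propyl there, and in this assay compound 3 gives 46700 nM. Either chain moves the series off the limit: an at least 3.1-fold lower number from compound 1 to compound 2 (0.49 log units; beyond the scatter) and an at least 2.1-fold lower number from compound 1 to compound 3 (0.33 log units; beyond the scatter). Between the two chain ends there is no separation that counts: a 1.5-fold higher number from compound 2 to compound 3 (0.17 log units; within the scatter). So compound 3 stands with compound 2 as one of only two numbers shown, the two within the scatter of each other, and the third entry is a limit rather than a number.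

Compound 4 `Cn1cc(C2=C(c3nn(CCCO)c4ncccc34)C(=O)NC2=O)c2ccccc21` is the next step from compound 3: hydroxy in place of 4-methylpiperazin-1-yl on a saturated chain carbon, three bonds along the chain from an aromatic nitrogen. Among the compounds with values here, the steps that bear on it are an at least 2.1-fold lower number from compound 1 to compound 3 (0.33 log units; beyond the scatter), showing that a chain on the aromatic nitrogen lifts the series off the limit, and a 1.5-fold higher number from compound 2 to compound 3 (0.17 log units; within the scatter), showing that swapping one chain end for another changed nothing beyond the scatter. Compound 4 keeps the propyl chain, now as 3-hydroxypropyl, so the step of a 1.3-fold higher number from compound 3 to compound 4 (0.11 log units; within the scatter) is expected to be small, at most a mild loss. For compound 4 the estimate in this assay is 60000 nM, with a range from 20000 nM to 150000 nM.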

Compound 4, half-maximal inhibitory concentration: 85800 nM
For compound 4 the middle estimate is 1.4-fold (0.16 log units) below the measured one, and the stated range covers the measured number.
By their numbers in this assay, from the lowest: compounds 2, 3 and 4 (each within the scatter of the next, the first and the last beyond it). At a limit, above all of these: compound 1.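

Notes on the new result. In this assay, hydroxy at the end of the propyl chain gives a 1.8-fold higher number from compound 3 to compound 4 (0.26 log units; within the scatter), so replacing the whole 4-methylpiperazin-1-yl ring with a single oxygen does not separate these two compounds. Within the data shown here, the comparison with the imidazole chain gives a 2.7-fold higher number from compound 2 to compound 4 (0.43 log units; beyond the scatter), a modest step and the first between two chain-bearing compounds to lie beyond the scatter. Read against compound 1, which is a limit and not a number, 3-hydroxypropyl gives an at least 1.1-fold lower number from compound 1 to compound 4 (0.06 log units; that floor lies within the scatter), so this chain, unlike the two that end in a ring, is not shown to move the series off that limit: the limit of > 100000 nM in this assay, at which 1 of the 4 values shown sits.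

The compounds shown leave open how a primary amine or a carboxylic acid at the end of the propyl chain would compare with hydroxy, and how a longer chain ending in hydroxy would read. Chain length and chain end differ together between compound 2 and compound 4, so the part of the butyl chain in that step cannot be told apart from the part of the imidazole ring.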